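This account rests on a few compounds, and the source may have more. Where it says the series, first, only, none or still open, it means among the compounds named here.

Measured in a functional assay (Nicotiana tabacum); a higher number here means a weaker inhibitor, a lower number a stronger inhibitor:
Compound 1 `CNc1nc(SC)nc2ncccc12`: 2920 nM
Compound 2 `CCCCCCNc1nc(SC)nc2ncccc12`: 3330 nM

Compound 2, at 3330 nM, stands level with compound 1, since the two numbers lie within the scatter of repeated measurements. The next compound to be tested, compound 3 `CSc1nc(NC2CC2)c2cccnc2n1`, has not yet been measured. It carries cyclopropyl in place of hexyl on a nitrogen on an aromatic ring.

Among the measured compounds shown here, only one measured step bears on this change. It is a 1.1-fold higher number from compound 1 to compound 2 (0.06 log units; within the scatter), made by pentyl in place of hydrogen on a saturated chain carbon bound to a nitrogen on an aromatic ring. That large change of chain left this assay without a shift beyond the scatter, which suggests some tolerance at this place. The evidence is thin, however, resting on a single pair, and neither measured compound has a ring there. So no real shift is expected, only a wide margin of doubt.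

The expected step is a 1.1-fold lower number from compound 2 to compound 3 (0.05 log units; within the scatter), which would be no change beyond the scatter. For compound 3 the estimated value is 3000 nM, with an expected range from 1000 nM to 9000 nM.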

Compound 3, half-maximal inhibitory concentration: 4900 nM
Compound 3: middle estimate off by 1.6-fold (0.21 log units), on the low side; the measured number falls inside the stated range.
By their numbers in this assay, from the lowest: compounds 1, 2 and 3 (each within the scatter of the next).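

In this assay, among the compounds shown here, compound 3 puts a ring on this nitrogen for the first time, and the change from hexyl to cyclopropyl gives a 1.5-fold higher number from compound 2 to compound 3 (0.17 log units; within the scatter) while the change from methyl to cyclopropyl gives a 1.7-fold higher number from compound 1 to compound 3 (0.22 log units; within the scatter) and so neither step moves the number beyond the scatter. The earlier pair showed only that a longer chain could replace a shorter one here without a clear shift; this result extends that tolerance to a three-membered ring of carbon, with methyl, hexyl and cyclopropyl all reading alike among these three compounds. No separate measurement is available to explain this flat result.

From the compounds shown here alone, it remains open whether any group on this nitrogen can shift the number beyond the scatter, for example a larger ring such as cyclohexyl, an aromatic ring such as phenyl, or a chain ending in an amine or a carboxylic acid. Going by these compounds, all three compounds also share the same core, so the effect of changes elsewhere on it remains unknown.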